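Methoxy to Triazole: Expected Solubility of Compound 4

The source may hold more compounds than are shown below. What is called first, only, known or untested is meant among the compounds shown, and "the series" means these compounds.

Of the compounds shown here, three sharing one core have been measured in a physicochemical assay for solubility, read by HPLC, with a stated time of 24 h; a lower number here means a less soluble compound, a higher number a more soluble compound. Compound 1 `CN(CCC#N)C[C@H]1CN(c2ccc(-n3cc(-c4ccccn4)cn3)c(F)c2)C(=O)O1` gives 64500 nM. Compound 2 `O=C1CSC(=O)N1C[C@H]1CN(c2ccc(-n3cc(-c4ccccn4)cn3)c(F)c2)C(=O)O1` gives 26900 nM, and compound 3 `COC[C@H]1CN(c2ccc(-n3cc(-c4ccccn4)cn3)c(F)c2)C(=O)O1` gives 36200 nM, which places compound 3 second highest of the three. Compound 4 `O=C1O[C@@H](Cn2ccnn2)CN1c1ccc(-n2cc(-c3ccccn3)cn2)c(F)c1` differs from compound 3 by 1H-1,2,3-triazol-1-yl in place of methoxy on a saturated chain carbon bound to a saturated ring carbon. The steps that exchanged the group at this same position bear on it: a 1.8-fold lower number from compound 1 to compound 3 (0.25 log units; within the scatter), a 1.3-fold higher number from compound 2 to compound 3 (0.13 log units; within the scatter), and a 2.4-fold lower number from compound 1 to compound 2 (0.38 log units; beyond the scatter), the last being the only one beyond the scatter. A modest change is expected in this assay, a 1.2-fold lower number from compound 3 to compound 4 (0.08 log units; within the scatter), with no firm direction. Compound 4 is therefore estimated at 30000 nM, within a range from 12000 nM to 70000 nM.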

Compound 4, solubility: 247000 nM
Compound 4: middle estimate off by 8.2-fold (0.92 log units), on the low side; measured number above the stated range.
By their numbers in this assay, from the lowest: compounds 2, 3 and 1 (each within the scatter of the next, the first and the last beyond it); then compound 4.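

In this assay, the group on this saturated chain carbon bound to a saturated ring carbon can shift the number much further than the exchanges among compounds 1, 2 and 3 suggested. 1H-1,2,3-triazol-1-yl sets compound 4 apart from all three, beyond the scatter each time (a 6.8-fold higher number from compound 3 to compound 4 (0.83 log units; beyond the scatter); a 9.2-fold higher number from compound 2 to compound 4 (0.96 log units; beyond the scatter); a 3.8-fold higher number from compound 1 to compound 4 (0.58 log units; beyond the scatter)). Nothing measured here accounts for this rise.

From the compounds shown here alone, whether the rise depends on this particular ring remains open. A 1H-pyrazol-1-yl or a primary amine on the same carbon could begin to show that.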